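The source may report more compounds than this note shows. Statements on the series, on what has been measured and on what is new or still open speak of the compounds shown alone.

Of the compounds shown here, three have so far been measured in a functional assay on PC-3 cells (Homo sapiens) for antiproliferative activity, read by MTT assay, tested at 1 uM; a higher number here means a stronger effect of the compound at the concentration tested, a lower number a weaker effect. Compound 1 `COc1ccc(C2OC(c3cc(OC)c(OC)c(OC)c3)=NN2C(C)=O)c(OC)c1` gives 69.5% and stands highest of the three. Compound 2 `COc1cc(C(=O)N/N=C/c2ccccc2C(F)(F)F)cc(OC)c1OC` gives 45% in this assay, a value beyond the scatter below that of compound 1. Compound 3 `COc1ccc(/C=N/NC(=O)c2cc(OC)c(OC)c(OC)c2)c(OC)c1` gives 10% in this assay and lies furthest below compound 1, again beyond the scatter. Compounds 2 and 3 are built differently from compound 1 in more than one place, so their gaps to it cannot be tied to any single change.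

Compound 4 `COc1cc(C2=NN(C(C)=O)C(c3ccc(F)cc3)O2)cc(OC)c1OC` has not yet been measured. It differs from compound 1 in one place: 4-fluorophenyl in place of 2,4-dimethoxyphenyl on a saturated ring carbon. Within the data shown here, no measured pair shows a change of this kind, so the size and direction of the step can only be estimated. The expected step from compound 1 to compound 4 is a number 24.5 percentage points lower from compound 1 to compound 4 (beyond the scatter), a loss beyond the scatter. Compound 4 is therefore expected to reach about 45% in this assay, with a likely range from 15% to 75%.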

Compound 4, a percentage reported as inhibition, at one concentration (the size of the read-out at that concentration, not a potency): 0%
Beside the measured number, compound 4's estimate is 45 percentage points above it, outside the stated range (below it).
By their numbers in this assay, from the lowest: compounds 4 and 3 (each within the scatter of the next); then compound 2; then compound 1.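

Among these compounds, this is the first change that can be read at a single place: in this assay, putting 4-fluorophenyl in place of 2,4-dimethoxyphenyl on the saturated ring carbon gives a number 69.5 percentage points lower from compound 1 to compound 4 (beyond the scatter). The group on this carbon therefore has a large bearing on the read-out at the concentration tested. The rest of the molecule is not enough on its own, as compound 4 keeps it unchanged and gives 0%. Nothing at hand gives a reason for the size of this loss.

This single swap removes two methoxy groups and brings in a fluorine, so the compounds shown cannot separate the effect of losing the methoxy groups from that of gaining the fluorine. As far as these compounds go, how a plain phenyl or a pyridyl group would read on this carbon also stays open.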